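A few compounds are considered here, and "the series" means these few. Any claim that something is new, unique, unknown or untested is made for them only; others in the source may bear on it.

Working notes on the series in an ADME assay on L6 cells (Rattus norvegicus) for cytotoxicity, read by resazurin assay, with a stated time of 72 h; on this read-out lower numbers stand for an effect already at smaller amounts and higher numbers for an effect only at larger amounts of compound.

Of the compounds shown here, two have numbers so far. Compound 1 `CCOC(=O)C1=C(C)N/C(=C/c2ccc(-c3ccc(C(F)(F)F)cc3)cc2)C1=O` gives 130000 nM in this assay. Compound 2 `CC1=C(C(=O)OCc2ccccc2)C(=O)/C(=C\c2cc(C)n(-c3ccccc3C(F)(F)F)c2C)N1` gives 57000 nM in this assay. Within the data shown here, of the two, compound 2 has the lower number, and the gap to compound 1 lies beyond the usual scatter of this assay, so compound 2 is the one of the pair that shows its effect at the smaller amount. Among the measured compounds shown here, no pair of measured compounds differs in one place only, so no single structural step has been read directly in this assay yet.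

Compound 3 `CC1=C(C(=O)N2CCCCC2)C(=O)/C(=C\c2cc(C)n(-c3ccccc3C(F)(F)F)c2C)N1` has not been measured. It differs from compound 2 by piperidin-1-yl in place of benzyloxy on a carbonyl carbon. With no measured step of this kind in the series, the size and direction of the change cannot be read from earlier numbers. The expectation is a small step, a 1.2-fold higher number from compound 2 to compound 3 (0.09 log units; within the scatter), which would sit within the scatter of repeated measurements rather than beyond it. For compound 3 the estimate in this assay is 70000 nM, with a range from 25000 nM to 200000 nM.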

Compound 3, half-maximal effective concentration: 26000 nM
Beside the measured number, compound 3's estimate is 2.7-fold (0.43 log units) above it; the measured number falls inside the stated range.
By their numbers in this assay, from the lowest: compound 3; then compound 2; then compound 1.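

In this assay, the series now has its first step that can be read at a single place: a 2.2-fold lower number from compound 2 to compound 3 (0.34 log units; beyond the scatter), a modest change that lies beyond the usual scatter. It shows that the group on this carbonyl carbon, whose other neighbours are a double-bonded ring carbon, can shift the read-out while the rest of compound 2 stays the same, which the earlier pair could not show. Benzyloxy, with its six-membered aromatic ring of carbon only, gives way here to piperidin-1-yl, with its six-membered non-aromatic ring holding a hetero atom, and the number falls; no measurement at hand ties this to any particular feature of either group.

A single step cannot show whether other groups on this carbonyl carbon, such as morpholin-4-yl, diethylamino or a free carboxylic acid, would move the number in the same direction or by a similar amount. Among these compounds, it also remains open whether the change would carry over to a different aryl group on the far side of the shared core, such as the one in compound 1.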